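A few compounds are considered here, and "the series" means these few. Any claim that something is new, unique, unknown or untested is made for them only; others in the source may bear on it.

Measured compounds:
- Compound 1, `C=C1C[C@]23C[C@@]1(O)CC[C@H]2c1ccc(OS(=O)(=O)c2ccc(C)cc2)c(C)c1[C@@H]3Cn1cc(-c2ccc(OC)cc2)nn1` — in a functional assay on A549 cells (Homo sapiens) for cytotoxicity, read by MTT assay, with a stated time of 4 days (on this read-out higher numbers stand for weaker inhibition and lower numbers for stronger inhibition), compound 1 gives > 20000 nM
- Compound 2, `C=C1C[C@]23C[C@@]1(O)CC[C@H]2c1ccc(O)c(C)c1[C@@H]3Cn1cc(-c2ccccc2)nn1` — in this assay compound 2 gives > 20000 nM

Both of these values are limits of the assay, not numbers: the measurement stopped at its ceiling without reaching a half-maximal effect. Compound 2 therefore stands at the edge of what this assay can report, and the same holds for compound 1, so the limit of > 20000 nM in this assay, at which 2 of the 2 values shown sit, describes the whole picture so far.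

Compound 3, `C=C1C[C@]23C[C@@]1(O)CC[C@H]2c1ccc(OS(=O)(=O)c2ccc(C)cc2)c(C)c1[C@@H]3Cn1cc(-c2ccccc2)nn1`, is not yet measured. It differs from compound 2 in one place: (4-methylphenyl)sulfonyl in place of hydrogen on an oxygen on an aromatic ring. In words, the hydroxy becomes a ((4-methylphenyl)sulfonyl)oxy. Compound 1 already carries this same group with a neighbouring methoxy-bearing phenyl, and it also sits at the limit. Nothing shown suggests a step beyond the scatter in either direction, so compound 3 is expected to stay near the ceiling, with an estimated step that the limit leaves unreadable from compound 2 to compound 3. The estimate for compound 3 is 30000 nM, with a range from 10000 nM to 100000 nM.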

Compound 3, half-maximal inhibitory concentration: > 20000 nM
Compound 3: only a limit was reported; the forecaster's own chance of this, stated with the estimate: 85%; the middle value does not contradict the limit.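

In this assay compound 3 gives > 20000 nM, which is a limit of the assay and not a number. No step from compound 1 or compound 2 to compound 3 can be read: the limit of > 20000 nM in this assay, at which 3 of the 3 values shown sit.

The compounds shown leave open whether any change to the shared core can bring a half-maximal effect within reach of this measurement.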